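The source may report more compounds than this note shows. Statements on the series, on what has been measured and on what is new or still open speak of the compounds shown alone.

In a functional assay on HeLa cells (Homo sapiens) for cytotoxicity, read by MTT assay (a higher number here means a weaker inhibitor, a lower number a stronger inhibitor), three compounds sharing one core have been measured so far. Compound 1 `CC(C)=CC[C@@H](OC[C@H](C)O)C1=CC(=O)c2c(O)ccc(O)c2C1=O` gives 40300 nM, compound 3 `CC(=O)OCCO[C@H](CC=C(C)C)C1=CC(=O)c2c(O)ccc(O)c2C1=O` gives 41500 nM, and compound 2 `CC(=O)OCCC(=O)O[C@H](CC=C(C)C)C1=CC(=O)c2c(O)ccc(O)c2C1=O` gives 17300 nM, the lowest number of the three and so the strongest inhibitor among them. The next compound, compound 4 `CC(C)=CC[C@@H](OC(=O)CC(O)c1ccccc1)C1=CC(=O)c2c(O)ccc(O)c2C1=O`, differs from compound 2 at the far end of its side chain: hydroxy(phenyl)methyl in place of acetoxymethyl on a saturated chain carbon bound to a carbonyl carbon. In words, hydroxy(phenyl)methyl stands in place of acetoxymethyl on a saturated chain carbon bound to a carbonyl carbon. The evidence for this change is indirect. Two measured steps are modest, a 2.3-fold lower number from compound 1 to compound 2 (0.37 log units; beyond the scatter) and a 2.4-fold higher number from compound 2 to compound 3 (0.38 log units; beyond the scatter), and both alter the carbonyl that compound 4 retains. A third step, which changes the chain end, is a 1.0-fold higher number from compound 1 to compound 3 (0.01 log units; within the scatter) and stays within the scatter. Among the measured compounds shown here, no measured compound carries a phenyl group, so that part remains untested. In this assay, no shift beyond the scatter is therefore expected, and the estimated step is a 1.1-fold lower number from compound 2 to compound 4 (0.03 log units; within the scatter). The expected value for compound 4 is 16000 nM, with an estimated range of 6000 nM to 42000 nM.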

Compound 4, half-maximal inhibitory concentration: 44500 nM
Estimate against measurement, compound 4: 2.8-fold (0.44 log units) below; the measured number lies above the stated range.
By their numbers in this assay, from the lowest: compound 2; then compounds 1, 3 and 4 (each within the scatter of the next).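

In this assay the change from acetoxymethyl to hydroxy(phenyl)methyl on a saturated chain carbon bound to a carbonyl carbon gives a 2.6-fold higher number from compound 2 to compound 4 (0.41 log units; beyond the scatter) and so shows that, with the carbonyl kept, the far end of this chain can move the number. Among the compounds shown here, the step is modest, yet it is the first one here that alters the chain end alone with the carbonyl in place and brings in an aromatic ring, which makes this end of the chain a part of the structure that counts. Nothing measured here explains why the number rises.

The change swaps several features at once, so a chain ending in plain phenyl and one ending in hydroxymethyl would be needed to separate the ring from the hydroxyl. From the compounds shown here alone, how an amine or a carboxylic acid at this place would read also remains open.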